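This account rests on a few compounds, and the source may have more. Where it says the series, first, only, none or still open, it means among the compounds named here.

Values in a functional assay on MCF7 cells (Homo sapiens) for antiproliferative activity, read by MTT assay, with a stated time of 72 h; a higher number here means a weaker inhibitor, a lower number a stronger inhibitor:
- Compound 1 `COc1cccc(N2C(=O)COc3ccc(-c4cnc(Cl)c(NS(=O)(=O)c5ccc(F)cc5)c4)cc32)c1`: > 40000 nM, a limit.
- Compound 2 `COc1ccc(N2C(=O)COc3ccc(-c4ccc(O)cc4)cc32)cc1`: 17300 nM.
- Compound 3 `COc1cccc(N2C(=O)COc3ccc(-c4cnc(OC)c(NS(=O)(=O)c5ccc(F)cc5)c4)cc32)c1`: > 40000 nM, a limit.

Compound 3 has only a limit, > 40000 nM, the one described in the limit of > 40000 nM in this assay, at which 2 of the 3 values shown sit. Compound 4 `COc1ncc(-c2ccc3c(c2)N(C(C)C)C(=O)CO3)cc1NS(=O)(=O)c1ccc(F)cc1` differs from it as follows: isopropyl in place of 3-methoxyphenyl on an amide-type nitrogen in a ring. Going by the values given here, the only measured step, a step that the two limits leave unreadable from compound 1 to compound 3, is a change of methoxy in place of chloro at another place and gives no size to carry over. Among the compounds with values here, compound 2, at 17300 nM, has the only numerical value in this assay, but no step links it to compound 4. The expected step, a number no higher from compound 3 to compound 4 (the limit leaves the size open), therefore has no firm direction and is expected to stay near the limit. For compound 4 the estimate is 40000 nM, with an expected range of 15000 nM to 100000 nM.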

Compound 4, half-maximal inhibitory concentration: 17000 nM
Beside the measured number, compound 4's estimate is 2.4-fold (0.37 log units) above it, within the range that was stated.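

Compared with the chloro-to-methoxy change, whose step cannot be read, the amide-type nitrogen in a ring gives the first readable step among these neighbours: isopropyl in place of 3-methoxyphenyl produces an at least 2.3-fold lower number from compound 3 to compound 4 (0.37 log units; beyond the scatter) in this assay. An aromatic ring is thus not needed on this nitrogen for a measurable number in this series. The size remains a minimum, since compound 3 has only a limit: the limit of > 40000 nM in this assay, at which 2 of the 4 values shown sit.

Open, on these data alone, is whether a methyl, a cyclohexyl ring or a longer chain ending in an amine on this nitrogen would lower the number further. Also open, as far as these compounds go, is whether isopropyl has the same effect with chloro in place of methoxy.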